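The source may report more compounds than this note shows. Statements on the series, on what has been measured and on what is new or still open speak of the compounds shown alone.

Measured so far in an ADME assay on MT4 cells (Homo sapiens) for cytotoxicity, read by MTT assay, with a stated time of 96 h; on this read-out lower numbers stand for higher toxicity in this test and higher numbers for lower toxicity in this test:

- compound 1, `O=C(CN1CCCC1)Nc1ccc(-c2nc3ccccc3[nH]2)cc1`, gives 40000 nM
- compound 2, `CC(=O)Nc1ccc(-c2nc3ccccc3[nH]2)cc1`, gives 100000 nM
- compound 3, `CCC(=O)Nc1ccc(-c2nc3ccccc3[nH]2)cc1`, gives 35000 nM

Compound 3 has the lowest of the three numbers, but its gap to compound 1 is within the scatter, a 1.1-fold lower number from compound 1 to compound 3 (0.06 log units; within the scatter); only compound 2 stands clearly apart from it, a 2.9-fold lower number from compound 2 to compound 3 (0.46 log units; beyond the scatter). The yet unmeasured compound 4, `O=C(CN1CCCCC1)Nc1ccc(-c2nc3ccccc3[nH]2)cc1`, differs from compound 3 in one place: piperidin-1-yl in place of methyl on a saturated chain carbon bound to a carbonyl carbon. For the measured compounds named here, the measured step that bears most closely on this change is the one from compound 1 to compound 3, where methyl took the place of a closely related ring, pyrrolidin-1-yl, on the same carbon and the number hardly moved, a 1.1-fold lower number from compound 1 to compound 3 (0.06 log units; within the scatter). Read in reverse, that step suggests that putting a ring of this kind back on that carbon should not shift the number beyond the scatter. Going by the values given here, no measured compound carries piperidin-1-yl itself, so the expectation rests on that single comparison. Compound 4 is therefore expected to give about 38000 nM in this assay , between 18000 nM and 80000 nM. The expected step from compound 3 to compound 4 is estimated as a 1.1-fold higher number from compound 3 to compound 4 (0.04 log units; within the scatter), which is within the scatter.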

Compound 4, half-maximal cytotoxic concentration: 31000 nM
Compound 4: middle estimate off by 1.2-fold (0.09 log units), on the high side; the measured number falls inside the stated range.
By their numbers in this assay, from the lowest: compounds 4, 3 and 1 (each within the scatter of the next); then compound 2.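

In this assay, piperidin-1-yl on the saturated chain carbon bound to the carbonyl carbon cannot be told apart from methyl (a 1.1-fold lower number from compound 3 to compound 4 (0.05 log units; within the scatter)) or from pyrrolidin-1-yl (a 1.3-fold lower number from compound 1 to compound 4 (0.11 log units; within the scatter)). Only hydrogen at this place stands clearly apart (a 3.2-fold lower number from compound 2 to compound 4 (0.51 log units; beyond the scatter)), so a group of six heavy atoms gives a number within the scatter of one that brings a single carbon, and the larger ring adds no measurable toxicity in this test. No measured evidence is available to explain why these groups read alike.

The compounds shown leave open whether the ring nitrogen matters at this place, which cyclohexyl, the same ring without its nitrogen, would test. They also leave open whether an open-chain amine such as dimethylamino or a ring such as morpholin-4-yl would give a similar number.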